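Isobutyl for cyclopropyl on the sulfonamide nitrogen

The source may report more compounds than this note shows. Statements on the series, on what has been measured and on what is new or still open speak of the compounds shown alone.

In a functional assay on MM1.S cells (Homo sapiens) for inhibition, with a stated time of 72 h (a lower number here means a stronger inhibitor, a higher number a weaker inhibitor), compound 1 `O=C(NO)c1ccc(CN(C2CC2)S(=O)(=O)c2cc(F)c(F)c(F)c2F)cc1` stands at 480 nM and compound 2 `CC(C)N(Cc1ccc(C(=O)NO)cc1)S(=O)(=O)c1c(F)c(F)c(F)c(F)c1F` at 440 nM with the two numbers within the scatter of each other. Within the data shown here, compound 3 `CC(C)CN(Cc1ccc(C(=O)NO)cc1)S(=O)(=O)c1cc(F)c(F)c(F)c1F` carries isobutyl in place of cyclopropyl on a sulfonamide nitrogen and no measured pair shows this change alone. In this assay no step beyond the scatter is expected in either direction, and the estimated 1.1-fold lower number from compound 1 to compound 3 (0.06 log units; within the scatter) stays within it. For compound 3 the expected value is 420 nM with an estimated range from 170 nM to 1000 nM.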

Compound 3, half-maximal inhibitory concentration: 690 nM
For compound 3 the middle estimate is 1.6-fold (0.22 log units) below the measured one; measured number inside the range.
By their numbers in this assay, from the lowest: compounds 2, 1 and 3 (each within the scatter of the next).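

In this assay the change at the sulfonamide nitrogen can now be read alone: isobutyl in place of cyclopropyl gives a 1.4-fold higher number from compound 1 to compound 3 (0.16 log units; within the scatter) and so no change beyond the scatter. At this place, the three-membered ring of cyclopropyl is therefore not required to keep the number within the scatter of compound 1. No available evidence bears on the reason for this result.

Still open, on these data alone, is whether a group of another kind on this nitrogen, such as an amine or a carboxylic acid, would stay within the scatter of compound 1.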